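A few compounds are considered here, and "the series" means these few. Any claim that something is new, unique, unknown or untested is made for them only; others in the source may bear on it.

Compounds measured so far:
compound 1 `CCCCCCCC/C=C/CCCCCCCC(=O)Nc1ccccc1OC`: 8000 nM
compound 2 `CCCCCCCC/C=C/CCCCCCCC(=O)Nc1ccccc1CC`: 1200 nM

Both compounds share a long unsaturated chain joined through an amide to a benzene ring carrying one substituent. In an assay on microsomes from intestine for inhibition of acyl-CoA:cholesterol acyltransferase (Oryctolagus cuniculus) (on this read-out higher numbers stand for weaker inhibition and lower numbers for stronger inhibition), compound 1 gives 8000 nM, while compound 2 gives 1200 nM, the lowest number of the two. Among the measured compounds shown here, the only step known is a 6.7-fold lower number from compound 1 to compound 2 (0.82 log units; beyond the scatter), which comes from putting ethyl in place of methoxy on an aromatic carbon.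

Compound 3 `CCCCCCCC/C=C/CCCCCCCC(=O)Nc1ccccc1C(C)C` goes one step further on that ethyl group: methyl in place of hydrogen on a saturated chain carbon bound to an aromatic carbon and a saturated chain carbon. For the measured compounds named here, no measured pair shows this exact change; the one step available swaps a methoxy for an alkyl group rather than enlarging an alkyl group. Because a 6.7-fold lower number from compound 1 to compound 2 (0.82 log units; beyond the scatter) pointed toward the alkyl, a small further gain or no change beyond the scatter seems the likeliest outcome. The expected step is a 1.5-fold lower number from compound 2 to compound 3 (0.18 log units; within the scatter). Compound 3 is expected to give 800 nM, with a range from 300 nM to 2500 nM.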

Compound 3, half-maximal inhibitory concentration: 600 nM
Compound 3: the middle estimate sits 1.3-fold (0.12 log units) above what was measured, within the range that was stated.
By their numbers in this assay, from the lowest: compounds 3 and 2 (each within the scatter of the next); then compound 1.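

In this assay, going from ethyl to isopropyl gives a 2.0-fold lower number from compound 2 to compound 3 (0.30 log units; within the scatter), so adding this methyl to the saturated chain carbon bound to an aromatic carbon has no effect that can be told apart from the scatter. The wider comparison is clearer: isopropyl in place of methoxy gives a 13-fold lower number from compound 1 to compound 3 (1.12 log units; beyond the scatter), so the branched group, like the unbranched ethyl, stands well apart from methoxy on this read-out. No outside evidence bears on this result, and the reason for the difference stays unknown.

The compounds shown leave open whether a still larger group here, such as tert-butyl or cyclohexyl, would hold this level or lose it. They also leave open how an amine or a carboxylic acid in this place would compare with the alkyl groups and with methoxy.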